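This account rests on a few compounds, and the source may have more. Where it says the series, first, only, none or still open, it means among the compounds named here.

Working notes on the series. The shared core is constant; compound 1 `CCCS(=O)(=O)Nc1ccc(F)c(C(=O)c2n[nH]c3ncc(-c4ccc(OC)cc4)cc23)c1F`, compound 2 `CCCS(=O)(=O)Nc1ccc(F)c(C(=O)c2n[nH]c3ncc(-c4ccccc4N)cc23)c1F` and compound 3 `CCCS(=O)(=O)Nc1ccc(F)c(C(=O)c2n[nH]c3ncc(-c4cccc(C(F)(F)F)c4)cc23)c1F` differ only in the aryl group on the aromatic carbon. In an assay for binding affinity to dual specificity mitogen-activated protein kinase kinase 4 (Homo sapiens), read by KINOMEscan, tested at 100 nM (on this read-out lower numbers stand for a stronger effect and higher numbers for a weaker effect at the one concentration tested), compound 1 gives 4.2%, compound 2 gives 23% and compound 3 gives 57%. Compound 3 therefore stands highest of the three, with the weakest binding on this read-out: a number 52.8 percentage points higher from compound 1 to compound 3 (beyond the scatter) and a number 34 percentage points higher from compound 2 to compound 3 (beyond the scatter), while a number 18.8 percentage points higher from compound 1 to compound 2 (beyond the scatter).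

Compound 4 `CCCS(=O)(=O)Nc1ccc(F)c(C(=O)c2n[nH]c3ncc(-c4ccc(S(=O)(=O)NCC)cc4)cc23)c1F` has not yet been measured. The change is 4-(ethylsulfamoyl)phenyl in place of 3-(trifluoromethyl)phenyl on an aromatic carbon. Both steps that lead into compound 3 are large and point the same way, so the aryl group clearly matters here, and the lowest number belongs to compound 1 with 4.2%, whose 4-methoxyphenyl, like the entering group, carries a hydrogen-bond acceptor. Among the compounds with values here, no measured step involves an ethylsulfamoyl group, so the expectation rests on the aryl series alone. Compound 4 is expected to come in well below compound 3, with an estimated a number 37 percentage points lower from compound 3 to compound 4 (beyond the scatter), giving an estimate of 20%, in the range 5% to 50%.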

Compound 4, a percentage reported as activity, at one concentration (the size of the read-out at that concentration, not a potency): 3%
For compound 4 the middle estimate is 17 percentage points above the measured one; measured number below the stated range.
By their numbers in this assay, from the lowest: compounds 4 and 1 (each within the scatter of the next); then compound 2; then compound 3.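

In this assay, 4-(ethylsulfamoyl)phenyl gives a number 54 percentage points lower from compound 3 to compound 4 (beyond the scatter) and a number 20 percentage points lower from compound 2 to compound 4 (beyond the scatter), so a much larger 4-substituent than methoxy is compatible with a low number at this aromatic carbon. The step to ethylsulfamoyl in place of methoxy is a number 1.2 percentage points lower from compound 1 to compound 4 (within the scatter), so the two 4-substituted phenyl groups cannot be told apart here, and both stand lower than 2-aminophenyl and 3-(trifluoromethyl)phenyl. No measurement on hand explains these differences.

In the compounds shown, the substituent's identity and its place on the phenyl ring change together, so 4-(trifluoromethyl)phenyl and 3-(ethylsulfamoyl)phenyl would be needed to separate the two. As far as these compounds go, it also remains open whether a carboxylic acid or an amine at the 4-place of the phenyl ring would keep the number as low.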